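The source may report more compounds than this note shows. Statements on the series, on what has been measured and on what is new or still open speak of the compounds shown alone.

Measured so far in a functional assay on the whole organism for antagonist activity, with Mus musculus as the target, in the maximal electroshock model; a lower number here means that less compound is needed, a higher number that more compound is needed for the effect:
Compound 1 `CSc1nnc(-c2ccc(F)cc2)n1C`: > 200 mg/kg, a limit
Compound 2 `CSc1nnc(-c2ccc(Cl)cc2)n1C`: > 200 mg/kg, a limit

Compound 2 thus stands only at a limit, and the limit of > 200 mg/kg in this assay, at which 2 of the 2 values shown sit, holds for both compounds. Compound 3 `CCn1c(SC)nnc1-c1ccc(Cl)cc1` has methyl in place of hydrogen on a saturated chain carbon bound to an aromatic nitrogen. For the measured compounds named here, the one measured step, a step that the two limits leave unreadable from compound 1 to compound 2, concerns chloro in place of fluoro, cannot be read and does not bear on this change. No size or direction can therefore be drawn from the data, and compound 3 is expected to stay near the limit of compound 2. The estimated step is a number no higher from compound 2 to compound 3 (the limit leaves the size open). For compound 3 the expected value is 200 mg/kg, with an estimated range from 80 mg/kg to 400 mg/kg.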

Compound 3, dose for half-maximal effect: > 50 mg/kg
Compound 3: only a limit was reported; the forecaster's own chance of this, stated with the estimate: 65%; the middle value does not contradict the limit.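

In this assay, for the compounds shown here, compound 3 gives > 50 mg/kg, a limit, so no step from compound 2 to compound 3 can be read. The compounds shown leave open whether methyl in place of hydrogen changes the dose needed at all.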